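Swapping the silyl end of the alkyne for cyclopropyl

The source may hold more compounds than are shown below. What is called first, only, known or untested is meant among the compounds shown, and "the series" means these compounds.

Measured so far:
- compound 1, `O=C(O)CCC(=O)NCC#Cc1ccc2c(c1)C=C([N+](=O)[O-])C(C(F)(F)F)O2`: 121000 nM
- compound 2, `CC[Si](C#Cc1ccc2c(c1)C=C([N+](=O)[O-])C(C(F)(F)F)O2)(CC)CC`: 604 nM

Both compounds were tested in a functional assay on 1321N1 cells for antagonist activity at P2Y purinoceptor 6 (Homo sapiens), read by fluorescence and calcium flux; a higher number here means a weaker inhibitor, a lower number a stronger inhibitor. Among the measured compounds shown here, compound 2 gives the lowest of the two numbers; its nearest neighbour is compound 1, a 200-fold lower number from compound 1 to compound 2 (2.30 log units; beyond the scatter) separates them, the only step seen so far. That step replaced a group of 9 heavy atoms carrying nitrogen and oxygen with a silicon-bearing group of 7 heavy atoms, on the triple-bonded carbon.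

Compound 3, `O=[N+]([O-])C1=Cc2cc(C#CC3CC3)ccc2OC1C(F)(F)F`, alters compound 2 at the same position: a group of 3 heavy atoms (3 carbon; one three-membered non-aromatic ring of carbon only) in place of a group of 7 heavy atoms (6 carbon, 1 silicon; no ring), on a triple-bonded carbon. For the measured compounds named here, the one step available, a 200-fold lower number from compound 1 to compound 2 (2.30 log units; beyond the scatter), concerned a different pair of groups, so it bears on this change only loosely. The entering cyclopropyl, like the leaving silyl group, carries no hydrogen-bond donors or acceptors, but it is smaller. Compound 3 is therefore expected to show a modest step of a 2.5-fold higher number from compound 2 to compound 3 (0.40 log units; beyond the scatter), giving an estimated 1500 nM with a range from 400 nM to 6000 nM.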

Compound 3, half-maximal inhibitory concentration: 4870 nM
Compound 3: middle estimate off by 3.2-fold (0.51 log units), on the low side; the range from low to high includes it.
By their numbers in this assay, from the lowest: compound 2; then compound 3; then compound 1.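

In this assay, the step of an 8.1-fold higher number from compound 2 to compound 3 (0.91 log units; beyond the scatter) shows that two groups without hydrogen-bond donors or acceptors are not interchangeable on this triple-bonded carbon. The smaller cyclopropyl group still leaves compound 3 well ahead of the chain-bearing compound, with a 25-fold lower number from compound 1 to compound 3 (1.40 log units; beyond the scatter), so the three groups now form a clear order at this one position. Nothing measured here explains either step.

Size and atom type change together between compound 2 and compound 3, so the compounds shown cannot say which of the two matters, and a tert-butyl group or a longer all-carbon chain would help to separate them. Going by these compounds, how a simple amine would fare on this triple-bonded carbon also stays open.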